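Moving the chlorine on the benzyl group of compound 2

A few compounds are considered here, and "the series" means these few. Any claim that something is new, unique, unknown or untested is made for them only; others in the source may bear on it.

Of the compounds shown here, three have been measured in a functional assay on DU-145 cells (Homo sapiens) for inhibition, read by trypan blue exclusion, with a stated time of 96 h; on this read-out higher numbers stand for weaker inhibition of growth and lower numbers for stronger inhibition of growth. Compound 1 `O=C(/C(=C\OCc1ccccc1)S(=O)(=O)c1ccccc1Cl)c1ccc(Cl)cc1` gives 1000 nM. Compound 2 `O=C(/C(=C\c1ccc(O)c([N+](=O)[O-])c1)SCc1ccccc1Cl)c1ccc(Cl)cc1` gives 10000 nM. Compound 3 `COc1cc(OC)c(/C=C(\C(=O)c2ccc(Cl)cc2)S(=O)(=O)c2ccc(C)cc2)c(OC)c1` gives 25000 nM.

On these numbers compound 2 stands second highest of the three. Its nearest neighbour is compound 3, whose number is higher by a margin that lies beyond the usual scatter of the assay, so compound 3 inhibits growth more weakly than compound 2. Compound 1 is furthest away, with a number lower than that of compound 2 by a margin well beyond the scatter, so compound 1 is the stronger inhibitor of the three that have been measured.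

Compound 4 `O=C(/C(=C\c1ccc(O)c([N+](=O)[O-])c1)SCc1ccc(Cl)cc1)c1ccc(Cl)cc1` has not yet been measured. It differs from compound 2 in one place, and the two contain the same atoms joined differently:

4-chlorophenyl in place of 2-chlorophenyl on a saturated chain carbon bound to a sulfur

Within the data shown here, no measured pair in this set shows what moving a chlorine around a ring of this kind does. Without such a pair, the expectation is a step from compound 2 to compound 4 of no change at the digits printed from compound 2 to compound 4 (within the scatter), that is, no change beyond the scatter in either direction. Compound 4 is therefore estimated at 10000 nM in this assay, with a range from 3000 nM to 30000 nM.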

Compound 4, concentration for 50% growth inhibition: 10000 nM
Estimate against measurement, compound 4: no gap at the digits printed, within the range that was stated.
By their numbers in this assay, from the lowest: compound 1; then compounds 2 and 4 (each within the scatter of the next); then compound 3.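

Among these compounds, this is the first pair in the set that differs in only one place, so it is the first direct look at this position. In this assay, moving the chlorine, with 4-chlorophenyl in place of 2-chlorophenyl on a saturated chain carbon bound to a sulfur, gives no change at the digits printed from compound 2 to compound 4 (within the scatter). For this pair, then, growth inhibition does not separate 2-chlorobenzyl from 4-chlorobenzyl, although the result covers only these two placements on this one core, and no measurement at hand offers an explanation for it.

On these data alone, whether the chlorine matters at all remains open, since a plain benzyl group, or a methoxy group, an amine or a carboxylic acid in place of the chlorine, could give a different number. As far as these compounds go, it is also open whether the same move of a chlorine would leave the number unchanged on the 2-chlorophenyl ring of compound 1, where the surrounding structure differs from that of compound 2 in more than one place.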